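Exchanging a 2-fluorophenyl group for 3,4,5-trimethoxyphenyl

A few compounds are considered here, and "the series" means these few. Any claim that something is new, unique, unknown or untested is made for them only; others in the source may bear on it.

Of the compounds shown here, three sharing one core have so far been measured in an ADME assay on L02 cells (Homo sapiens) for cytotoxicity, read by MTT assay, with a stated time of 24 h; on this read-out higher numbers stand for weaker inhibition and lower numbers for stronger inhibition. Compound 1 (`CC(=O)Nc1ccc(S(=O)(=O)N2C/C(=C\c3cccc([N+](=O)[O-])c3)C(=O)/C(=C/c3cccc([N+](=O)[O-])c3)C2)cc1`) carries 3-nitrophenyl twice and gives 15800 nM there. Compound 2 (`COc1cc(/C=C2\CN(S(=O)(=O)c3ccc(NC(C)=O)cc3)C/C(=C\c3cc(OC)c(OC)c(OC)c3)C2=O)cc(OC)c1OC`) carries 3,4,5-trimethoxyphenyl twice and gives 13600 nM there. Compound 3 (`CC(=O)Nc1ccc(S(=O)(=O)N2C/C(=C\c3cccc([N+](=O)[O-])c3)C(=O)/C(=C/c3ccccc3F)C2)cc1`) carries one 3-nitrophenyl and one 2-fluorophenyl and stands at 18400 nM within the scatter of both others, so the three numbers form no order.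

The difference 3,4,5-trimethoxyphenyl in place of 2-fluorophenyl on a double-bonded chain carbon bound to a double-bonded ring carbon leads to compound 4 (`COc1cc(/C=C2\CN(S(=O)(=O)c3ccc(NC(C)=O)cc3)C/C(=C\c3cccc([N+](=O)[O-])c3)C2=O)cc(OC)c1OC`), which keeps the 3-nitrophenyl and so combines one group of compound 1 with one of compound 2. Among the measured compounds shown here, the only measured step at this place (a 1.2-fold higher number from compound 1 to compound 3 (0.07 log units; within the scatter)) exchanged 3-nitrophenyl for 2-fluorophenyl. Compound 2 at 13600 nM and compound 1 at 15800 nM also lie within the scatter of each other, so no step beyond the scatter is expected in this assay for this exchange. The expected step is small (a 1.2-fold lower number from compound 3 to compound 4 (0.09 log units; within the scatter)) and its direction cannot be relied on. For compound 4 the estimated value is 15000 nM with an expected range from 8500 nM to 26000 nM in this measurement.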

Compound 4, half-maximal inhibitory concentration: 15600 nM
Compound 4: middle estimate off by 1.0-fold (0.02 log units), on the low side; the range from low to high includes it.
By their numbers in this assay, from the lowest: compounds 2, 4, 1 and 3 (each within the scatter of the next).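

In this assay, the exchange at this place gave a 1.2-fold lower number from compound 3 to compound 4 (0.07 log units; within the scatter), although 3,4,5-trimethoxyphenyl brings 12 heavy atoms and 3 hydrogen-bond acceptors where 2-fluorophenyl has 7 and 0. Compound 4 also links the two compounds that carry the same group twice: replacing one 3-nitrophenyl gave a 1.0-fold lower number from compound 1 to compound 4 (0.01 log units; within the scatter), and replacing one 3,4,5-trimethoxyphenyl gave a 1.1-fold higher number from compound 2 to compound 4 (0.06 log units; within the scatter), so the mixed pair of groups stands within the scatter of both matched pairs and the earlier lack of order now holds for direct single exchanges at this place. Nothing available accounts for this flat result.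

As far as these compounds go, all the groups compared at this place are substituted phenyl rings, so it remains open whether a phenyl ring bearing a dimethylamino group or a carboxylic acid, or a saturated ring such as cyclohexyl, would give a step beyond the scatter. From the compounds shown here alone, it also remains open whether the other place on the shared core, or the acetamide on the sulfonyl-bound phenyl ring, would respond differently to such exchanges in this assay.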